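The source may report more compounds than this note shows. Statements on the series, on what has been measured and on what is new or still open speak of the compounds shown alone.

In a functional assay on MDA-MB-435 cells (Homo sapiens) for cytotoxicity, read by sulforhodamine B assay, with a stated time of 48 h (on this read-out higher numbers stand for lower toxicity in this test and lower numbers for higher toxicity in this test), three compounds built on a chlorinated bicyclic core carrying the same benzyl arm have been measured. Compound 1, `ClCc1ccccc1Cn1cnc2c(Cl)nc(Cl)nc21`, gives 6450 nM. Compound 2, `ClCc1ccccc1Cn1cnc2c(Cl)ncnc21`, gives 36300 nM. Compound 3, `ClCc1ccccc1Cn1cnc2ncnc(Cl)c21`, gives 7580 nM, which puts it close to compound 1 and well apart from compound 2.

The one single-point step among these is a 5.6-fold lower number from compound 2 to compound 1 (0.75 log units; beyond the scatter), the change being (chloro in place of hydrogen on an aromatic carbon). Between compound 2 and compound 3 the same atoms are joined differently, and the difference between the two cores is not broken down here; their values alone show compound 3 with the markedly lower number.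

Compound 4, `ClCc1ccccc1Cn1cnc2nc(Cl)nc(Cl)c21`, has not yet been measured in this assay. It differs from compound 3 by chloro in place of hydrogen on an aromatic carbon. Going by the values given here, this is the same change as the one from compound 2 to compound 1, made on the core of compound 3 rather than that of compound 2. Because a 5.6-fold lower number from compound 2 to compound 1 (0.75 log units; beyond the scatter) went beyond the scatter, compound 4 is expected to land at a lower number than compound 3 by a step of about a 4.2-fold lower number from compound 3 to compound 4 (0.62 log units; beyond the scatter), somewhat tempered since the core it is made on is not the same. The estimate for compound 4 is 1800 nM, with a range from 600 nM to 5500 nM.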

Compound 4, concentration lethal to 50% of the cells: 58900 nM
Compound 4: the middle estimate sits 33-fold (1.51 log units) below what was measured; measured number above the stated range.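

In this assay, chloro in place of hydrogen on an aromatic carbon gave a 7.8-fold higher number from compound 3 to compound 4 (0.89 log units; beyond the scatter), so on this core the number rose, whereas on the other core the same change lowered it, and the two steps clearly differ: the same change on two cores in this assay, a 5.6-fold lower number (0.75 log units; beyond the scatter) from compound 2 to compound 1 and a 7.8-fold higher number (0.89 log units; beyond the scatter) from compound 3 to compound 4, 44-fold (1.64 log units) apart, beyond the scatter of two such steps For this series, then, neither the direction nor the size of the step can be carried from one core to the other, and a step read on one core is a poor guide to the outcome on the second. The result does not show what in the two cores sets the steps apart, and two pairs of compounds cannot say how the change would behave on any further core.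

The compounds shown carry only chloro or hydrogen at the place between two ring nitrogen atoms, so it remains open whether an amine or a methoxy group there would follow the step on one core, the step on the other, or neither. From the compounds shown here alone, it is also open whether the two cores would still part in this way with a hydroxymethyl group in place of the chloromethyl group on the benzyl arm.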